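A few compounds are considered here, and "the series" means these few. Any claim that something is new, unique, unknown or untested is made for them only; others in the source may bear on it.

Compound 1 `Cc1ccc(C(=O)N/N=C/c2cc(I)cc(I)c2O)cc1` and compound 2 `O=C(N/N=C/c1cc(I)c(O)c(I)c1)c1ccccc1` were both examined in a functional assay on HepG2 cells (Homo sapiens) for cytotoxicity, with a stated time of 24 h; a higher number here means a weaker inhibitor, a lower number a stronger inhibitor. For compound 1, this assay reports only a limit, > 25000 nM, and not a number. Going by the values given here, compound 2 gives 191000 nM in this assay, and this is the only number among the values shown. The remaining value, that of compound 1, is a limit, as stated in the limit of > 25000 nM in this assay, at which 1 of the 2 values shown sits. Compound 3 `O=C(N/N=C/c1cc(I)c(O)c(I)c1)c1ccc([N+](=O)[O-])cc1` has not yet been measured in this assay. It differs from compound 2 in one place: nitro in place of hydrogen on an aromatic carbon. Among the compounds with values here, no step between two measured compounds is available, so the size of such a change in this assay cannot be read from any measured pair. Compound 2 stands at 191000 nM, a weak level in this assay. The step of a 1.6-fold lower number from compound 2 to compound 3 (0.20 log units; within the scatter) is expected to lie within the scatter, or only a little beyond it, toward a somewhat stronger inhibitor. Compound 3 is therefore estimated at 120000 nM in this assay, in a range from 40000 nM to 400000 nM.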

Compound 3, half-maximal inhibitory concentration: 92100 nM
Estimate against measurement, compound 3: 1.3-fold (0.11 log units) above; the measured number falls inside the stated range.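

Placing nitro in place of hydrogen gives a 2.1-fold lower number from compound 2 to compound 3 (0.32 log units; beyond the scatter) in this assay, the first measured size of a change on this aromatic carbon of a six-membered aromatic ring of carbon only, para to a large group. The position therefore accepts a group of three heavy atoms with a modest move toward a stronger inhibitor, and compound 3, at 92100 nM, does not leave the weak range in which compound 2 stands. Going by these compounds alone, compound 1 contributes only a limit and not a number, and no steps involving it can be read: the limit of > 25000 nM in this assay, at which 1 of the 3 values shown sits.

This single step leaves open whether the shift belongs to nitro in particular or would also appear with an amine, a carboxylic acid or a methoxy group on the same carbon, and nothing shown connects it to any measured property of the nitro group. From the compounds shown here alone, it also remains open whether the same change would give a step of similar size on the core of compound 1.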